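Swapping the 4-fluorophenyl group of compound 2

This account rests on a few compounds, and the source may have more. Where it says the series, first, only, none or still open, it means among the compounds named here.

Measured in a functional assay on A549 cells (Homo sapiens) for antiproliferative activity, read by MTT assay, with a stated time of 72 h; a higher number here means a weaker inhibitor, a lower number a stronger inhibitor:
- compound 1 `O=C(N/N=C/c1ccc(F)cc1)Nc1ccc(Oc2ccnc3[nH]ccc23)c(F)c1`: 680 nM
- compound 2 `O=C(N/N=C/c1ccc(F)cc1)Nc1ccc(Oc2ccnc3[nH]ccc23)cc1`: 1430 nM

Of the two, compound 2 stands higher, at 1430 nM, and is the weaker inhibitor in this assay. Compound 3 `O=C(N/N=C/c1ccc(O)cc1Br)Nc1ccc(Oc2ccnc3[nH]ccc23)cc1` keeps the rest of compound 2 and changes one group: 2-bromo-4-hydroxyphenyl in place of 4-fluorophenyl on a carbon with a double bond to nitrogen. Thus 2-bromo-4-hydroxyphenyl comes in place of 4-fluorophenyl on a carbon with a double bond to nitrogen. Going by the values given here, the one measured step, a 2.1-fold higher number from compound 1 to compound 2 (0.32 log units; beyond the scatter), is modest, swaps hydrogen in place of fluoro on an aromatic carbon and does not touch this place. It therefore bears only loosely on the change, as a guide to how far a small edit can move the number, and the data give no direction. The expected step is small, a 1.1-fold higher number from compound 2 to compound 3 (0.05 log units; within the scatter), with wide uncertainty either way. Compound 3 is estimated at 1600 nM, with a range from 400 nM to 5500 nM.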

Compound 3, half-maximal inhibitory concentration: 5080 nM
The estimate for compound 3 lay 3.2-fold (0.50 log units) below the measured number; measured number inside the range.
By their numbers in this assay, from the lowest: compound 1; then compound 2; then compound 3.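

In this assay, going by these compounds alone, the earlier compounds showed only a change elsewhere in the molecule, and this result shows that the group on a carbon with a double bond to nitrogen also moves the number: putting 2-bromo-4-hydroxyphenyl in place of 4-fluorophenyl gives a 3.6-fold higher number from compound 2 to compound 3 (0.55 log units; beyond the scatter). The swap is a joint one, since the entering group carries bromine and oxygen, with one hydrogen-bond donor and one acceptor where the leaving group has none, so the step belongs to the whole group and not to either substituent alone. No measurement at hand explains the step.

Going by these compounds, it remains open how a 2-bromophenyl or a 4-hydroxyphenyl group alone would read here, which would separate the two substituents. Also open, on these data alone, is how a 4-aminophenyl group or a carboxylic acid would read at this place.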